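The source may report more compounds than this note shows. Statements on the series, on what has been measured and on what is new or still open speak of the compounds shown alone.

Working notes on a series of chloroquinoline amines measured for solubility.

Compound 1 `Clc1ccc2c(NCCCOc3nccc(Cl)n3)ccnc2c1` gives 200 nM in a physicochemical assay for solubility, read by HPLC, in phosphate buffer, with a stated time of 24 h, at pH 7.4; on this read-out lower numbers stand for lower solubility and higher numbers for higher solubility. Compound 2 `Clc1ccc2c(NCCCCNc3nccc(Cl)n3)ccnc2c1` gives 700 nM in this assay. Going by the values given here, compound 3 `Clc1ccc2c(NCCNc3ccnc(Cl)n3)ccnc2c1` gives 680 nM in this assay, which places it second highest of the three numbers so far: it sits within the scatter of compound 2, and stands beyond the scatter above compound 1.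

Compound 4 `Clc1ccc2c(NCCNc3nccc(Cl)n3)ccnc2c1` has not yet been measured in this assay. It differs from compound 3 by 4-chloropyrimidin-2-yl in place of 2-chloropyrimidin-4-yl on an amine nitrogen. The two compounds share every atom and differ only in how they are joined. Among the compounds with values here, no measured pair shows this particular swap on its own, so the size of the step cannot be read from the data; with compound 2 already carrying 4-chloropyrimidin-2-yl and giving 700 nM, no step beyond the scatter is expected in either direction.

The expected step is a 1.1-fold lower number from compound 3 to compound 4 (0.05 log units; within the scatter) in this assay. Compound 4 is therefore estimated at 600 nM, with a range from 250 nM to 1500 nM.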

Compound 4, solubility: 900 nM
Beside the measured number, compound 4's estimate is 1.5-fold (0.18 log units) below it, within the range that was stated.
By their numbers in this assay, from the lowest: compound 1; then compounds 3, 2 and 4 (each within the scatter of the next).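

Going by these compounds alone, the swap of 2-chloropyrimidin-4-yl for 4-chloropyrimidin-2-yl on an amine nitrogen, with the same atoms joined differently, gives the first pair that differs in one place, and in this assay it reads as a 1.3-fold higher number from compound 3 to compound 4 (0.12 log units; within the scatter). At this place, the way the chloropyrimidine ring is joined therefore produces no step beyond the scatter, and neither of the two arrangements can be ranked above the other. Nothing measured here speaks to the reason for this outcome.

Within the data shown here, it remains open whether the same swap would also stay within the scatter on a longer chain, such as the one carried by compound 2. Equally open, from the compounds shown here alone, is what a morpholine or a carboxylic acid in place of the chlorine on the pyrimidine would do to the read-out.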